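Fluoro for methyl on the benzyl ring of compound 2

The source may hold more compounds than are shown below. What is called first, only, known or untested is meant among the compounds shown, and "the series" means these compounds.

Compound 1 `Cc1c(Cc2ccc(F)cc2)c(=O)oc2cc(OCC(O)CN3CCC(C(N)=O)CC3)ccc12`: 89300 nM
Compound 2 `Cc1cc(F)ccc1Cc1c(C)c2ccc(OCC(O)CN3CCC(C(N)=O)CC3)cc2oc1=O`: > 100000 nM

In an ADME assay on A549 cells (Homo sapiens) for cytotoxicity, read by CellTiter-Glo (a higher number here means that more compound is tolerated, a lower number that less compound is tolerated), compound 1 gives 89300 nM. For compound 2 the value is only a limit of the assay, > 100000 nM, and it sits at the limit of > 100000 nM in this assay, at which 1 of the 2 values shown sits. Compound 3 `Cc1c(Cc2ccc(F)cc2F)c(=O)oc2cc(OCC(O)CN3CCC(C(N)=O)CC3)ccc12` differs from compound 2 by fluoro in place of methyl on an aromatic carbon. Among the compounds with values here, the single measured step, an at least 1.1-fold higher number from compound 1 to compound 2 (0.04 log units; that floor lies within the scatter), touches the same aromatic carbon and stays within the scatter. Compound 3 is therefore expected to show no step beyond the scatter, an at least 1.0-fold lower number from compound 2 to compound 3 (0.02 log units; that floor lies within the scatter). The estimate for compound 3 is 95000 nM, with a range from 45000 nM to 200000 nM.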

Compound 3, half-maximal cytotoxic concentration: > 100000 nM
Compound 3: only a limit was reported; the forecaster's own chance of this, stated with the estimate: 50%; at least 1.0-fold (0.02 log units) between middle value and limit.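

With fluoro on this aromatic carbon, this assay again ends at a limit, as it does with methyl in compound 2 and now in compound 3: the limit of > 100000 nM in this assay, at which 2 of the 3 values shown sit. Against hydrogen in compound 1, fluoro gives an at least 1.1-fold higher number from compound 1 to compound 3 (0.04 log units; that floor lies within the scatter), so this second substituent also shows no change beyond the scatter, though that figure is only a floor. The step between compound 2 and compound 3 cannot be read, since both values are limits.

As far as these compounds go, the true order of methyl and fluoro on this carbon stays open. So does whether a methoxy group or an amine here would bring the value down from the limit.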